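This account rests on a few compounds, and the source may have more. Where it says the series, first, only, none or still open, it means among the compounds named here.

Three measured compounds share one core and differ at two places. Compound 1 `CCCCc1ccc2[nH]c(-c3ccc(OC)cc3)c(/C=N/NC(=O)c3ccccc3)c2c1` is the reference; in a functional assay on MCF7 cells (Homo sapiens) for antiproliferative activity, with a stated time of 5 days (a lower number here means a stronger inhibitor, a higher number a weaker inhibitor), compound 1 gives 130 nM. Compound 2 `CCCCc1ccc2[nH]c(-c3ccc(C(F)(F)F)cc3)c(/C=N/NC(=O)c3ccccc3)c2c1` differs from it by trifluoromethyl in place of methoxy on an aromatic carbon, and in this assay compound 2 gives 460 nM, which is a 3.5-fold higher number from compound 1 to compound 2 (0.55 log units; beyond the scatter). Compound 3 `CCCCc1ccc2[nH]c(-c3ccc(OC)cc3)c(/C=N/NC(=O)c3ccccn3)c2c1` differs from compound 1 by pyridin-2-yl in place of phenyl on a carbonyl carbon; in this assay compound 3 gives 160 nM, and the result is a 1.2-fold higher number from compound 1 to compound 3 (0.09 log units; within the scatter), so the two values are not told apart.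

Compound 4 `CCCCc1ccc2[nH]c(-c3ccc(C(F)(F)F)cc3)c(/C=N/NC(=O)c3ccccn3)c2c1` has not yet been measured. Its difference from compound 3 is trifluoromethyl in place of methoxy on an aromatic carbon, described at a place that reads word for word the same as before, so it is the same change as from compound 1 to compound 2, occurring twice in all. Going by the values given here, the only difference between the cores of the two pairs is the one already given for compound 3.

For compound 4 a step of about a 3.5-fold higher number from compound 3 to compound 4 (0.54 log units; beyond the scatter) is expected, resting on the earlier step of a 3.5-fold higher number from compound 1 to compound 2 (0.55 log units; beyond the scatter) made by the same change. Compound 4 is therefore estimated at 560 nM in this assay, likely between 280 nM and 1100 nM.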

Compound 4, half-maximal inhibitory concentration: 310 nM
Compound 4: middle estimate off by 1.8-fold (0.26 log units), on the high side; the range from low to high includes it.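

In this assay, trifluoromethyl in place of methoxy gives a 1.9-fold higher number from compound 3 to compound 4 (0.29 log units; within the scatter), and this step cannot be told apart from the same change made earlier on the core with phenyl on the carbonyl: the same change on two cores in this assay, a 3.5-fold higher number (0.55 log units; beyond the scatter) from compound 1 to compound 2 and a 1.9-fold higher number (0.29 log units; within the scatter) from compound 3 to compound 4, 1.8-fold (0.26 log units) apart, within the scatter of two such steps. Pyridin-2-yl in place of phenyl gives a 1.5-fold lower number from compound 2 to compound 4 (0.17 log units; within the scatter), and this change also carries over from the methoxy compounds to the trifluoromethyl compounds without a detectable difference: the same change on two cores in this assay, a 1.2-fold higher number (0.09 log units; within the scatter) from compound 1 to compound 3 and a 1.5-fold lower number (0.17 log units; within the scatter) from compound 2 to compound 4, 1.8-fold (0.26 log units) apart, within the scatter of two such steps. The four compounds therefore fit the two changes adding up independently, but they do not fix the size of the trifluoromethyl step, which is beyond the scatter on one core and within it on the other, and two pairs cannot show that this holds across the wider series.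

The compounds shown leave open whether an amine or a carboxylic acid in the place of methoxy would carry over in the same way. They also leave open whether either change would hold up on a core with a longer chain in place of butyl.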